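Compound 4: nitro in place of methoxy

A few compounds are considered here, and "the series" means these few. Any claim that something is new, unique, unknown or untested is made for them only; others in the source may bear on it.

Compound 3 `COc1ccc(S(=O)(=O)Oc2ccccc2/C=C(\C#N)C(=O)Nc2nnc(Cc3ccccc3)s2)cc1` gives 23% in an ADME assay on HEK-293T cells (Homo sapiens) for inhibition, read by CCK-8 assay, with a stated time of 48 h, tested at 20 uM; on this read-out lower numbers stand for less inhibition of growth and higher numbers for more inhibition of growth at the one concentration tested. That value lies within the scatter of compound 1 `COc1ccc(Cc2nnc(NC(=O)/C(C#N)=C/c3ccccc3OS(=O)(=O)c3ccc([N+](=O)[O-])cc3)s2)cc1` at 17% and of compound 2 `Cc1ccc(S(=O)(=O)Oc2ccccc2/C=C(\C#N)C(=O)Nc2nnc(Cc3ccccc3)s2)cc1` at 15%, so the three cannot be ranked.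

Compound 4 `N#C/C(=C\c1ccccc1OS(=O)(=O)c1ccc([N+](=O)[O-])cc1)C(=O)Nc1nnc(Cc2ccccc2)s1` departs from compound 3 by nitro in place of methoxy on an aromatic carbon, para to a large group, which reads as 4-methoxyphenyl to 4-nitrophenyl.

Going by the values given here, one measured step bears on the same aromatic carbon: a number 8 percentage points higher from compound 2 to compound 3 (within the scatter), with methoxy in place of methyl, and it stays within the scatter. Compound 4 also shares the (4-nitrophenyl)sulfonyl group with compound 1, which differs from it elsewhere and gives 17%. Neither observation points to a step beyond the scatter in this assay, and no direction is expected.

The estimated change is a number 4 percentage points lower from compound 3 to compound 4 (within the scatter), which is not expected to exceed the scatter. For compound 4 the expected value is 19%, with an estimated range of 8% to 32%.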

Compound 4, percent growth inhibition at one concentration: "not toxic" (no number reported)
Compound 4 has no reported number here, so the estimate cannot be set against anything.
By their numbers in this assay, from the lowest: compounds 2, 1 and 3 (each within the scatter of the next).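

In this assay, going by these compounds alone, compound 4 carries only the verbal report "not toxic" and no number, so no step from compound 3 can be read. Going by these compounds, whether nitro in place of methoxy shifts growth inhibition stays open, and no evidence bears on this result.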